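Restoring a bromo group after a nitrile

This account rests on a few compounds, and the source may have more. Where it says the series, first, only, none or still open, it means among the compounds named here.

Compound 1 `COc1cc2ncnc(Nc3ccc(F)c(Br)c3)c2cc1OCCCN1CCNCCNCCNCC1`: 11800 nM
Compound 2 `COc1cc2ncnc(Nc3ccc(C#N)cc3F)c2cc1OCCCN1CCNCCNCCNCC1`: > 50000 nM

Both values come from a functional assay on A549 cells (Homo sapiens) for antiproliferative activity, read by MTT assay, with a stated time of 72 h; on this read-out lower numbers stand for stronger inhibition and higher numbers for weaker inhibition. Compound 2 stands at > 50000 nM, which is a limit and not a number. Compound 3 `CCc1cc(Br)ccc1Nc1ncnc2cc(OC)c(OCCCN3CCNCCNCCNCC3)cc12` has 4-bromo-2-ethylphenyl in place of 4-cyano-2-fluorophenyl on a nitrogen on an aromatic ring. Within the data shown here, the only measured step bearing on this is an at least 4.2-fold higher number from compound 1 to compound 2 (0.62 log units; beyond the scatter), which also replaced a bromo-bearing group with the nitrile-bearing one. Compound 3 brings a bromo group back, so a lower number in this assay, of similar size to that step, is expected. The expected change is an at least 3.1-fold lower number from compound 2 to compound 3 (0.49 log units; beyond the scatter). Compound 3 is estimated at 16000 nM, with a range of 5000 nM to 50000 nM.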

Compound 3, half-maximal inhibitory concentration: > 50000 nM
Compound 3: only a limit was reported; the forecaster's own chance of this, stated with the estimate: 25%; middle value at least 3.1-fold (0.49 log units) from the limit.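

In this assay compound 3 gives > 50000 nM, which is a limit and not a number. Carrying a bromo group is therefore not enough on this ring: 4-bromo-2-ethylphenyl in place of 3-bromo-4-fluorophenyl gives an at least 4.2-fold higher number from compound 1 to compound 3 (0.62 log units; beyond the scatter). The step between compound 2 and compound 3 cannot be read, because both sit at the same limit: the limit of > 50000 nM in this assay, at which 2 of the 3 values shown sit.

The compounds shown do not separate the effect of the ethyl group from that of the bromo group's different place on the ring. They also leave open whether a chloro or trifluoromethyl group there would give a measurable value.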